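Swapping Phenyl for Pyridin-2-yl on a Sulfonyl Group

A few compounds are considered here, and "the series" means these few. Any claim that something is new, unique, unknown or untested is made for them only; others in the source may bear on it.

Going by the values given here, compound 1 `CNCc1cc(-c2cccnc2F)n(S(=O)(=O)c2ccccc2)c1` stands at one end of the two numbers measured so far. In a physicochemical assay for lipophilicity, read by HPLC, at pH 7.4 (on this read-out higher numbers stand for higher lipophilicity and lower numbers for lower lipophilicity), compound 1 gives -0.09. In this assay compound 2 `CNCc1cc(-c2cccnc2C#N)n(S(=O)(=O)c2ccccc2)c1` gives -0.32, and the step of a number 0.23 log units lower from compound 1 to compound 2 (within the scatter) lies within the scatter. Compound 3 `CNCc1cc(-c2cccnc2F)n(S(=O)(=O)c2ccccn2)c1` changes a different part of the molecule: pyridin-2-yl in place of phenyl on a sulfonyl sulfur. Among the compounds with values here, the single measured step concerns cyano in place of fluoro, not the group on the sulfonyl sulfur, so no measured step bears directly on this change. A drop in this assay beyond the scatter is nevertheless expected, an estimated step of a number 0.71 log units lower from compound 1 to compound 3 (beyond the scatter). Compound 3 is estimated at -0.8, between -1.3 and -0.3.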

Compound 3, distribution coefficient: 0.05
The estimate for compound 3 lay 0.85 log units below the measured number; the whole stated range lies below it.
By their numbers in this assay, from the lowest: compounds 2, 1 and 3 (each within the scatter of the next, the first and the last beyond it).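

On a sulfonyl sulfur, pyridin-2-yl in place of phenyl gives a step in this assay that cannot be told apart from repeat scatter, a number 0.14 log units higher from compound 1 to compound 3 (within the scatter), so this single exchange leaves the reading effectively unmoved. Going by these compounds alone, this is the first measured change at this position, and it joins a swap of one aromatic ring for another with the same heavy-atom count. No supporting measurement is available to explain this result.

As far as these compounds go, whether the exchange would read the same with the cyano group of compound 2 in place of fluoro stays open. So does how this assay would respond to a non-aromatic group on the sulfonyl sulfur, such as methyl or cyclohexyl.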